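A few compounds are considered here, and "the series" means these few. Any claim that something is new, unique, unknown or untested is made for them only; others in the source may bear on it.

Compound 2 `Cc1nc(N2CCC(NS(=O)(=O)N(C)C)CC2)nc2ccc(NC(=O)/C=C/c3ccc(OC(F)(F)F)cc3)cc12` holds the lowest number of the three measured: in an assay on CHO-K1 cells for displacement of a labelled ligand from melanin-concentrating hormone receptor 1 (Homo sapiens), read by scintillation proximity assay, with a stated time of 2 h (on this read-out lower numbers stand for stronger inhibition and higher numbers for weaker inhibition), compound 2 gives 105 nM, while compound 3 `COCCC1(O)CCN(c2nc(C)c3cc(NC(=O)/C=C/c4ccc(Cl)cc4)ccc3n2)CC1` gives 245 nM and compound 1 `Cc1nc(N(C)C2CCCC2)nc2ccc(NC(=O)/C=C/c3ccc(Cl)cc3)cc12` gives 399 nM. Compound 4 `Cc1nc(N2CCC(N3CCNC3=O)CC2)nc2ccc(NC(=O)/C=C/c3ccc(OC(F)(F)F)cc3)cc12` differs from compound 2 by 2-oxoimidazolidin-1-yl in place of (dimethylsulfamoyl)amino on a saturated ring carbon. Going by the values given here, no measured step touches that saturated ring carbon; the only single-point step, a 1.6-fold lower number from compound 1 to compound 3 (0.21 log units; within the scatter), altered the group on the aromatic carbon and stayed within the scatter, so it gives no direct guidance on what this exchange might do. Among the compounds with values here, with no closer precedent, the expectation for compound 4 in this assay is a step of about a 1.1-fold higher number from compound 2 to compound 4 (0.06 log units; within the scatter), that is, none beyond the scatter. Compound 4 is therefore estimated at 120 nM, with a range from 40 nM to 360 nM.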

Compound 4, half-maximal inhibitory concentration: 66 nM
The estimate for compound 4 lay 1.8-fold (0.26 log units) above the measured number; the range from low to high includes it.
By their numbers in this assay, from the lowest: compounds 4 and 2 (each within the scatter of the next); then compounds 3 and 1 (each within the scatter of the next).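

In this assay, going by these compounds alone, the step of a 1.6-fold lower number from compound 2 to compound 4 (0.20 log units; within the scatter) is the first at this saturated ring carbon. It shows that a five-membered ring, 2-oxoimidazolidin-1-yl, can take the place of the open-chain (dimethylsulfamoyl)amino without a shift beyond the scatter. No measurement offers an explanation for this result. Going by these compounds, it remains open whether an amine or a carboxylic acid at this carbon would also stay within the scatter. On these data alone, it is also open whether 2-oxoimidazolidin-1-yl would give a similar number with chlorine in place of the trifluoromethoxy group.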